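The compounds below may be only part of what the source reports. "The series", "measured", "known", "first", "only" and "open" are said of these compounds alone.

Series notes. Among the measured compounds shown here, compound 2 `COc1ccccc1-n1cc2nc(CCCc3ccccc3)nc(N)c2n1` is one of two compounds so far measured in an assay on CHO cells for displacement of a labelled ligand from adenosine receptor A1 (Homo sapiens), read by scintillation counting, with a stated time of 120 min (a lower number here means a stronger inhibitor, a higher number a weaker inhibitor), where compound 2 gives 49 nM. Compound 1 `Nc1nc(Cc2ccccc2)nc2cn(-c3ccccc3O)nc12` differs from compound 2 in two places; in this assay compound 1 gives 52 nM, and the two values lie within the scatter of each other, so neither compound can be set above the other; compound 2 holds the lower of the two numbers only nominally. The next compound, compound 3 `Nc1nc(CCCc2ccccc2)nc2cn(-c3ccccc3O)nc12`, is reached from compound 2 by a single change: hydrogen in place of methyl on an oxygen on an aromatic ring. For the measured compounds named here, no measured pair shows this change on its own. Because compound 1 already carries the hydroxy form and gives 52 nM in this assay, on a par with compound 2, no step beyond the scatter is expected in either direction. For compound 3 the expected value is 45 nM, with a range of 20 nM to 100 nM, the expected step being a 1.1-fold lower number from compound 2 to compound 3 (0.04 log units; within the scatter).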

Compound 3, inhibition constant: 17 nM
Beside the measured number, compound 3's estimate is 2.6-fold (0.42 log units) above it; the whole stated range lies above it.
By their numbers in this assay, from the lowest: compound 3; then compounds 2 and 1 (each within the scatter of the next).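

Among the compounds shown here, changing 2-methoxyphenyl to 2-hydroxyphenyl gives a 2.9-fold lower number from compound 2 to compound 3 (0.46 log units; beyond the scatter) in this assay and is the first reading of this change on its own, with the lower number on the hydroxy side. With the hydroxy form held fixed, phenethyl in place of phenyl on a saturated chain carbon bound to an aromatic carbon gives a 3.1-fold lower number from compound 1 to compound 3 (0.49 log units; beyond the scatter) as a second single change, so both changes carry a step beyond the scatter, which the earlier pair, differing in two places, could not show. Nothing measured here speaks to the origin of either step.

The compounds shown leave open whether the methoxy to hydroxy step holds on the shorter chain of compound 1. They also leave open how an amine in place of the hydroxy on the aromatic ring, or a longer chain than that of compound 3, would read.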